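Trifluoromethoxy for Trifluoromethyl: What Compound 3 Might Show

The source may hold more compounds than are shown below. What is called first, only, known or untested is meant among the compounds shown, and "the series" means these compounds.

Compound 1, `CCC(CC)(CC(=O)Nc1cccc(OCc2ccc3ccc(Cl)cc3n2)c1)C(=O)O`: 0.8 nM
Compound 2, `CCC(CC)(CC(=O)Nc1cccc(OCc2ccc3ccc(C(F)(F)F)cc3n2)c1)C(=O)O`: 3 nM

Going by the values given here, in a functional assay on ileum (Cavia porcellus) for antagonist activity at cysteinyl leukotriene receptor (Homo sapiens) (a lower number here means a stronger inhibitor, a higher number a weaker inhibitor), compound 2 stands at the higher of the two numbers; its nearest neighbour is compound 1, and the only step, a 3.8-fold higher number from compound 1 to compound 2 (0.57 log units; beyond the scatter), lies beyond the scatter. Compound 3, `CCC(CC)(CC(=O)Nc1cccc(OCc2ccc3ccc(OC(F)(F)F)cc3n2)c1)C(=O)O`, carries trifluoromethoxy in place of trifluoromethyl on an aromatic carbon. Among the compounds with values here, no measured step covers this exact exchange; the one step recorded concerns a different group at the same place and was modest. The account therefore expects for compound 3 a change no change at the digits printed from compound 2 to compound 3 (within the scatter), small and of uncertain direction, in this assay. Compound 3 is estimated at 3 nM, within 1 nM to 10 nM.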

Compound 3, half-maximal inhibitory concentration: 9 nM
The estimate for compound 3 lay 3.0-fold (0.48 log units) below the measured number, and the stated range covers the measured number.
By their numbers in this assay, from the lowest: compound 1; then compound 2; then compound 3.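

In this assay, the place that already separated chloro from trifluoromethyl responds to a further exchange, with trifluoromethoxy raising the number again (a 3.0-fold higher number from compound 2 to compound 3 (0.48 log units; beyond the scatter)). Set against chloro, the same group gives a large step (an 11-fold higher number from compound 1 to compound 3 (1.05 log units; beyond the scatter)), so the three groups stand apart beyond the scatter, with chloro at the lowest number. Nothing at hand explains this order. From the compounds shown here alone, whether fluoro, bromo, methyl or a nitrile at this place would match chloro remains open, and so does whether this order would hold with another group in place of the diethyl-substituted acid chain.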